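Sulfonamide-amine series: aryl change on the sulfonyl sulfur

A few compounds are considered here, and "the series" means these few. Any claim that something is new, unique, unknown or untested is made for them only; others in the source may bear on it.

Measured so far:
- compound 1 `Cc1ccc(C)c(S(=O)(=O)NCCCCCCNCc2ccc(Br)cc2)c1`: 12000 nM
- compound 2 `O=S(=O)(NCCCNCc1cccc2ccccc12)c1cc(C(F)(F)F)cc(C(F)(F)F)c1`: 2800 nM
- compound 3 `O=S(=O)(NCCCNCc1ccc(Cl)cc1)c1cc(C(F)(F)F)cc(C(F)(F)F)c1`: 2800 nM

In a functional assay on MIA PaCa-2 cells (Homo sapiens) for inhibition, read by MTT assay, with a stated time of 72 h (on this read-out lower numbers stand for stronger inhibition of growth and higher numbers for weaker inhibition of growth), compound 1 gives 12000 nM, the highest number of the three; compound 2 and compound 3 both stand below it, and the gap to each lies beyond the scatter. Among the measured compounds shown here, the one measured step, no change at the digits printed from compound 2 to compound 3 (within the scatter), swaps the aryl on the amine side of the chain and leaves the sulfonyl aryl untouched; it bears only loosely on the present change. For the measured compounds named here, no measured step alters the group on the sulfonyl sulfur, so the size of such a change is unknown here.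

Compound 4 `O=S(=O)(NCCCCCCNCc1ccc(Br)cc1)c1ccccc1Cl` differs from compound 1 by 2-chlorophenyl in place of 2,5-dimethylphenyl on a sulfonyl sulfur. Going by the values given here, with no step of this kind measured, and the only measured step showing no change, the expectation is a small step, direction uncertain, likely within or near the scatter.

Compound 4 is expected to give 9000 nM (from 3000 nM to 25000 nM). The expected step is then a 1.3-fold lower number from compound 1 to compound 4 (0.12 log units; within the scatter).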

Compound 4, concentration for 50% growth inhibition: 13700 nM
Compound 4: middle estimate off by 1.5-fold (0.18 log units), on the low side; measured number inside the range.
By their numbers in this assay, from the lowest: compounds 2 and 3 (each within the scatter of the next); then compounds 1 and 4 (each within the scatter of the next).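

Among the compounds shown here, the first measured swap on the sulfonyl sulfur gives a 1.1-fold higher number from compound 1 to compound 4 (0.06 log units; within the scatter) in this assay and leaves the rest of the core of compound 1 in place. At this position, 2-chlorophenyl and 2,5-dimethylphenyl therefore cannot be told apart on this read-out, although this single pair sets no pattern for other aryl groups. No measured evidence bears on why these two groups read alike.

From the compounds shown here alone, compound 2 and compound 3 differ from compound 1 and compound 4 in more than one place, so it remains open how much their sulfonyl aryl and their chain each contribute. Also open, going by these compounds, is how an unsubstituted phenyl, a phenyl carrying trifluoromethyl groups or a pyridine ring on the sulfonyl sulfur would read with the rest of compound 1 kept.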